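From carboxy(fluoro)methyl to 1-carboxy-1-fluoroethyl

The source may report more compounds than this note shows. Statements on the series, on what has been measured and on what is new or still open speak of the compounds shown alone.

In an ADME assay on cells (Hepatocyte, Homo sapiens) for metabolic stability, read by LC-MS, with a stated time of 2 h, tested at 10 uM (a lower number here means that less of the compound is left, a higher number that more of the compound is left), compound 1 `COc1ccc(F)c([C@H]2CC[C@H](COc3cccc([C@@H](CC(=O)O)C4CC4)c3)CC2)c1` gives 56%, compound 2 `COc1ccc(F)c([C@H]2CC[C@H](COc3cccc([C@H](C4CC4)[C@H](C)C(=O)O)c3)CC2)c1` gives 45% and compound 3 `COc1ccc(F)c([C@H]2CC[C@H](COc3cccc([C@H](C4CC4)[C@@H](F)C(=O)O)c3)CC2)c1` gives 63%. Compound 3 thus lies within the scatter of compound 1 and clearly apart from compound 2, with a number 18 percentage points higher from compound 2 to compound 3 (beyond the scatter).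

Compound 4 `COc1ccc(F)c([C@H]2CC[C@H](COc3cccc([C@H](C4CC4)[C@@](C)(F)C(=O)O)c3)CC2)c1` differs from compound 3 by 1-carboxy-1-fluoroethyl in place of carboxy(fluoro)methyl on a saturated chain carbon bound to an aromatic carbon and a saturated ring carbon. Going by the values given here, two measured steps bear on this change. Fluoro in place of hydrogen gave a number 7 percentage points higher from compound 1 to compound 3 (within the scatter), which stays within the scatter. Among the compounds with values here, no measured compound carries both methyl and fluoro on that carbon, so whether the two steps add up is unknown. The methyl step is the better guide: methyl in place of hydrogen gave a number 11 percentage points lower from compound 1 to compound 2 (beyond the scatter), a modest step beyond the scatter. A similar modest fall is therefore expected here, a number 11 percentage points lower from compound 3 to compound 4 (beyond the scatter). For compound 4 the estimated value is 52%, with an expected range of 38% to 66%.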

Compound 4, percent of the compound remaining: 73%
Beside the measured number, compound 4's estimate is 21 percentage points below it, and the stated range ends below it.
By their numbers in this assay, from the lowest: compound 2; then compounds 1, 3 and 4 (each within the scatter of the next, the first and the last beyond it).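

In this assay, the methyl that went with a fall when it replaced hydrogen in compound 2 brings no such fall once fluoro sits on the same carbon, with a number 10 percentage points higher from compound 3 to compound 4 (within the scatter). Fluoro and methyl together therefore do not behave as the methyl step alone suggested: compound 4 stands clear of the methyl-only compound, with a number 28 percentage points higher from compound 2 to compound 4 (beyond the scatter), and clear of the compound with neither group, with a number 17 percentage points higher from compound 1 to compound 4 (beyond the scatter), whereas fluoro alone in compound 3 stayed within the scatter of compound 1. Nothing at hand accounts for this reversal of the methyl step.

The compounds shown leave open whether a hydroxyl or a chlorine in place of the fluoro would also remove the fall seen with methyl. They also leave open whether an ethyl in place of the methyl would keep the number of compound 4, and how the opposite configuration at that carbon would read.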